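The source may report more compounds than this note shows. Statements on the series, on what has been measured and on what is new or still open speak of the compounds shown alone.

Among the measured compounds shown here, the three compounds measured so far share one core: compound 1 is `Cc1c(C(=O)N/N=C/c2ccc([N+](=O)[O-])cc2)no[n+]1[O-]`, compound 2 is `Cc1c(C(=O)N/N=C/c2ccccc2)no[n+]1[O-]`, and compound 3 is `Cc1c(C(=O)N/N=C/c2ccccc2O)no[n+]1[O-]`. In an ADME assay on J774.1 cells (Mus musculus) for cytotoxicity, read by MTT assay, with a stated time of 48 h (a lower number here means a stronger inhibitor, a higher number a weaker inhibitor), compound 1 gives only a limit of the assay, > 300000 nM. In this assay compound 2 likewise gives only a limit, > 400000 nM. In this assay compound 3 gives 246000 nM. Compound 2 thus stands at a limit, and since one of the other two values is also a limit, its place among the three cannot be fixed further. The step that the two limits leave unreadable from compound 1 to compound 2 is left unreadable by the two limits the limit of > 300000 nM in this assay, at which 1 of the 3 values shown sits, and (the limit of > 400000 nM in this assay, at which 1 of the 3 values shown sits). The step of an at least 1.6-fold lower number from compound 2 to compound 3 (0.21 log units; that floor lies within the scatter).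

Compound 4, `Cc1c(C(=O)N/N=C/c2ccco2)no[n+]1[O-]`, differs from compound 2 in one place: furan-2-yl in place of phenyl on a carbon with a double bond to nitrogen. Neither measured step exchanges one ring for another, so a step that the two limits leave unreadable from compound 1 to compound 2 and an at least 1.6-fold lower number from compound 2 to compound 3 (0.21 log units; that floor lies within the scatter) bear on this change only indirectly, and together they show that changes at the phenyl moved the numbers little or not readably. Little movement beyond the scatter is therefore expected, and most likely another limit. The step expected for compound 4 is a number no higher from compound 2 to compound 4 (the limit leaves the size open) in this assay. Compound 4 is estimated at 400000 nM, within a range from 200000 nM to 1000000 nM.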

Compound 4, half-maximal inhibitory concentration: > 400000 nM
Compound 4: a limit, no number (the forecaster's own chance of this, stated with the estimate: 70%); the middle value sits exactly at the limit.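

In this assay compound 4 gives only a limit, > 400000 nM. Compound 2 also stands at a limit, so no step from compound 2 to compound 4 can be read, because neither gives a number: the limit of > 400000 nM in this assay, at which 2 of the 4 values shown sit.

The compounds shown leave open whether furan-2-yl in place of phenyl changes the number in this assay at all, and by how much.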